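Repeating an Amine Substituent Swap on a Second Core

The source may report more compounds than this note shows. Statements on the series, on what has been measured and on what is new or still open speak of the compounds shown alone.

Of the compounds shown here, three have been measured in a physicochemical assay for solubility, with a stated time of 18 h, at pH 7.4 (a higher number here means a more soluble compound, a lower number a less soluble compound), and one awaits measurement. Compound 1 `c1ccc(Cc2ccc3c(NCCCNCc4ccco4)ccnc3c2)cc1` gives 4200 nM in this assay. Compound 2 `COc1ccc(F)cc1CNCCCNc1ccnc2cc(Cc3ccccc3)ccc12` gives 4200 nM in this assay. Compound 3 `COc1ccc(-c2ccc3c(NCCCNCc4ccco4)ccnc3c2)cc1` gives 32000 nM in this assay, the highest of the three numbers.

Compound 2 differs from compound 1 by 5-fluoro-2-methoxyphenyl in place of furan-2-yl on a saturated chain carbon bound to an amine nitrogen, and that step read no change at the digits printed from compound 1 to compound 2 (within the scatter). Compound 3 differs from compound 1 in its core by 4-methoxyphenyl in place of benzyl on an aromatic carbon, and that step read a 7.6-fold higher number from compound 1 to compound 3 (0.88 log units; beyond the scatter). Among the compounds with values here, no step between compound 2 and compound 3 is broken down here; their two values simply stand as given.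

Compound 4 `COc1ccc(-c2ccc3c(NCCCNCc4cc(F)ccc4OC)ccnc3c2)cc1` has not yet been measured. It differs from compound 3 by 5-fluoro-2-methoxyphenyl in place of furan-2-yl on a saturated chain carbon bound to an amine nitrogen. This is the same change as the one from compound 1 to compound 2, at the same place, word for word; among the compounds shown it occurs twice in all. The cores on which it is made differ as described between compound 1 and compound 3.

Within the data shown here, for compound 4 the step expected in this assay is no change at the digits printed from compound 3 to compound 4 (within the scatter), which rests on the single earlier instance, no change at the digits printed from compound 1 to compound 2 (within the scatter), where the same change left the number essentially where it stood. On these data alone, whether that carries over to the core of compound 3 is untested, so the range is kept broad. The number estimated for compound 4 in this assay is 32000 nM, expected to fall between 13000 nM and 75000 nM.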

Compound 4, solubility: 32000 nM
Compound 4: middle estimate and measured number agree at the digits printed; measured number inside the range.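

In this assay, 5-fluoro-2-methoxyphenyl in place of furan-2-yl on a saturated chain carbon bound to an amine nitrogen gave no change at the digits printed from compound 3 to compound 4 (within the scatter) and, on the other core, no change at the digits printed from compound 1 to compound 2 (within the scatter), so the change read the same on both cores shown. The core difference also read the same with either group on the chain, as a 7.6-fold higher number from compound 2 to compound 4 (0.88 log units; beyond the scatter) stands alongside a 7.6-fold higher number from compound 1 to compound 3 (0.88 log units; beyond the scatter), and none of the four compounds goes against this. It remains a single square of two cores and two groups, which shows that the change carried over once but not that it would do so on any other core, and nothing at hand bears on why the number held under this change or moved with the core.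

The compounds shown leave open whether the same reading would hold for other groups in place of furan-2-yl, such as a carboxylic acid, a morpholine or a simple unsubstituted phenyl, or with a longer chain carrying the amine nitrogen. They also leave open how the change would read on a third core, for instance one bearing a pyridine in place of 4-methoxyphenyl.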